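A Hydroxy Added to the Phenethyl Arm of Compound 2

The compounds below may be only part of what the source reports. "The series", "measured", "known", "first", "only" and "open" are said of these compounds alone.

Compound 1 `C=C(CCC=C(C)C)[C@H](O)Cc1c(O)cc(O)cc1CCc1ccccc1` and compound 2 `CC1=CCc2c(O)cc(CCc3ccccc3)cc2OC1` were both examined in a functional assay on U-251 cells (Homo sapiens) for cytotoxicity, read by MTT assay, with a stated time of 48 h; a higher number here means a weaker inhibitor, a lower number a stronger inhibitor. In this assay compound 1 gives 9100 nM. For compound 2, this assay reports only a limit, > 40000 nM, not a number, and the limit of > 40000 nM in this assay, at which 1 of the 2 values shown sits, marks where that limit stands. Compound 3 `CC1=CCc2c(O)cc(CCc3ccccc3O)cc2OC1` is the partner of compound 2 with one change: hydroxy in place of hydrogen on an aromatic carbon. Among the compounds with values here, no measured pair in this set shows what this change does, so there is no ground to expect a step beyond the scatter in either direction in this assay. Compound 3 is therefore expected to remain near the limit, at an estimated 40000 nM, within 15000 nM to 100000 nM. The expected step is a number no higher from compound 2 to compound 3 (the limit leaves the size open), and a second limit rather than a number would not be surprising.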

Compound 3, half-maximal inhibitory concentration: 38600 nM
Estimate against measurement, compound 3: 1.0-fold (0.02 log units) above; low and high end bracket the measured number.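

With 2-hydroxyphenyl in place of phenyl, the series gains its first number on the core of compound 2: in this assay compound 3 gives 38600 nM. Compound 2 has only a limit, > 40000 nM. Hydroxy on this aromatic carbon, ortho to a large group, is thus read as an at least 1.0-fold lower number from compound 2 to compound 3 (0.01 log units; that floor lies within the scatter), and the true size of the step stays unknown, with its reading tied to this limit: the limit of > 40000 nM in this assay, at which 1 of the 3 values shown sits.

The compounds shown leave open whether a methoxy group or an amine at the same place would give a step beyond the scatter. They also leave open whether hydroxy on another carbon of that ring would read differently in this assay.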